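The source may hold more compounds than are shown below. What is called first, only, known or untested is meant among the compounds shown, and "the series" means these compounds.

Compound 1 `COc1ccccc1C(=O)NCc1ccc(CNS(=O)(=O)c2cccc3ccccc23)cc1` in an assay on MDA-MB-231 cells for displacement of a labelled ligand from C-X-C chemokine receptor type 4 (Homo sapiens), read by fluorescence and microscopy, with stated times of 10 min and 30 min (a higher number here means that more compound is needed for the effect, a lower number that less compound is needed), gives > 1000 nM, which is a limit of the assay and not a number.
Compound 2 `COc1ccccc1C(=O)NCc1ccc(CNS(=O)(=O)c2ccc(F)cc2)cc1` gives 100 nM.
Compound 3 `O=C(NCc1ccc(CNS(=O)(=O)c2cccc3ccccc23)cc1)c1cccnc1` gives 1000 nM.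

The two measured cores differ in one place: pyridin-3-yl in place of 2-methoxyphenyl on a carbonyl carbon. The step of a number no higher from compound 1 to compound 3 (the limit leaves the size open) cannot be sized, since the value of compound 1 is only a limit (the limit of > 1000 nM in this assay, at which 1 of the 3 values shown sits).

The change 4-fluorophenyl in place of naphthalen-1-yl on a sulfonyl sulfur produced the step of an at least 10-fold lower number from compound 1 to compound 2 (1.00 log units; beyond the scatter). Because compound 1 sits at the limit (the limit of > 1000 nM in this assay, at which 1 of the 3 values shown sits), the true size of that step may be larger than the limit shows.

Compound 4 `O=C(NCc1ccc(CNS(=O)(=O)c2ccc(F)cc2)cc1)c1cccnc1` has not been measured. It differs from compound 3 by 4-fluorophenyl in place of naphthalen-1-yl on a sulfonyl sulfur, the same change as that from compound 1 to compound 2, on a sulfonyl sulfur whose other neighbours are the same.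

Resting on the step of an at least 10-fold lower number from compound 1 to compound 2 (1.00 log units; beyond the scatter) and on compound 3 at 1000 nM, the expected step in this assay is a 10-fold lower number from compound 3 to compound 4 (1.00 log units; beyond the scatter). Compound 4 is thus estimated at 100 nM, with a likely range from 30 nM to 300 nM.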

Compound 4, effective concentration (reported as EC, without a stated level of effect): 100 nM
Compound 4: middle estimate and measured number agree at the digits printed, within the range that was stated.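

In this assay, 4-fluorophenyl in place of naphthalen-1-yl on the sulfonyl sulfur gives a 10-fold lower number from compound 3 to compound 4 (1.00 log units; beyond the scatter), while pyridin-3-yl in place of 2-methoxyphenyl on the carbonyl carbon gives no change at the digits printed from compound 2 to compound 4 (within the scatter). The sulfonyl change lowers the number on both cores, but compound 1 gives only a limit and not a number, so how closely the two steps match in size stays unsettled: the same change on two cores in this assay, an at least 10-fold lower number (1.00 log units; beyond the scatter) from compound 1 to compound 2 and a 10-fold lower number (1.00 log units; beyond the scatter) from compound 3 to compound 4; the limit leaves it open whether they differ For the carbonyl change, too, no comparison of size can be read, and two cores do not establish a rule for the whole series: the same change on two cores in this assay, a number no higher (the limit leaves the size open) from compound 1 to compound 3 and no change at the digits printed (within the scatter) from compound 2 to compound 4; the limit leaves it open whether they differ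

The compounds shown leave open how a methyl group or a longer alkyl chain would behave on the sulfonyl sulfur, and how an amine or a carboxylic acid would behave in place of pyridin-3-yl on the carbonyl carbon. They also leave open whether the sulfonyl change would carry over to a core with a third group on that carbonyl carbon.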